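The compounds below may be only part of what the source reports. "The series", "measured", "known", "first", "only" and "open" are said of these compounds alone.

Compound 1 `O=C(CCCCC(S)CCS)NO` - 58%
Compound 2 `O=C(CCCCC(S)CCS)Nc1ccccc1` - 15.8%
Compound 3 `O=C(CCCCC(S)CCS)Nc1ccc(Cl)cc1` - 44.1%

In a functional assay on KB cells (Homo sapiens) for inhibition, read by MTT assay, with a stated time of 24 h, tested at 100 ug/mL (on this read-out higher numbers stand for more inhibition of growth at the one concentration tested and lower numbers for less inhibition of growth), compound 2 gives 15.8%, the lowest of the three numbers. It is the plain anilide-type member of this small set, and it serves here as the starting point for compound 4 `Cc1cccc(NC(=O)CCCCC(S)CCS)c1`. The change is methyl in place of hydrogen on an aromatic carbon, meta to a large group.

Two measured steps can be compared with this change. The closer guide is a number 28.3 percentage points higher from compound 2 to compound 3 (beyond the scatter), which also adds a group to the aromatic ring, though a chloro rather than a methyl. The other, a number 42.2 percentage points lower from compound 1 to compound 2 (beyond the scatter), is a change on the amide-type nitrogen and says little about a ring substituent. Among the compounds with values here, no methyl compound has been measured, so the chloro step is only a loose guide. A rise smaller than the chloro step seems the most reasonable expectation, and it may not clear the usual scatter. The expected change is a number 8.2 percentage points higher from compound 2 to compound 4 (within the scatter). For compound 4 the estimated value is 24%, with an expected range from 12% to 40%.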

Compound 4, percent growth inhibition at one concentration: 17.5%
Compound 4: the middle estimate sits 6.5 percentage points above what was measured; measured number inside the range.
By their numbers in this assay, from the lowest: compounds 2 and 4 (each within the scatter of the next); then compound 3; then compound 1.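

In this assay, methyl in place of hydrogen on an aromatic carbon, meta to a large group, gives a number 1.7 percentage points higher from compound 2 to compound 4 (within the scatter) and so leaves the read-out of the plain anilide effectively unchanged. Before this result the only ring change on record was a number 28.3 percentage points higher from compound 2 to compound 3 (beyond the scatter) and it could have suggested that adding a group to the ring tends to raise the number, but the methyl shows that this does not hold for every group. Nothing available here explains why this small group at this place makes no measurable difference.

The compounds shown leave open whether an amine, a methoxy or a carboxylic acid at this same ring carbon would move the number. They also leave open whether chloro at this place would match the step seen for compound 3.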